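A few compounds are considered here, and "the series" means these few. Any claim that something is new, unique, unknown or untested is made for them only; others in the source may bear on it.

Measured in a functional assay on A549 cells (Homo sapiens) for cytotoxicity, read by MTT assay, with a stated time of 72 h; on this read-out lower numbers stand for stronger inhibition and higher numbers for weaker inhibition:

- compound 1 `CNC(=O)c1cc(Oc2ccc(NC(=O)c3nccc(-c4ccccc4)n3)cc2)ccn1`: 26200 nM
- compound 2 `CNC(=O)c1cc(Oc2ccc(NC(=O)c3cc(-c4ccc(Br)cc4)ncn3)cc2F)ccn1`: > 100000 nM

Among the measured compounds shown here, compound 1 holds the only actual number in this small set, so it is the natural reference point. Compound 2 gives > 100000 nM, which is a limit of the assay and not a number. With only the limit of > 100000 nM in this assay, at which 1 of the 2 values shown sits, to set beside it, compound 1 cannot be placed within any real spread of values.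

Compound 3 `CNC(=O)c1cc(Oc2ccc(NC(=O)c3nccc(-c4ccc(C)cc4)n3)cc2)ccn1` is compound 1 with one small edit: methyl in place of hydrogen on an aromatic carbon. A methyl takes the place of hydrogen on an aromatic carbon, para to a large group, so phenyl becomes 4-methylphenyl.

For the measured compounds named here, no two measured compounds differ in one place only, so this assay offers no direct guide to what such an edit does. With so small a change, the expectation stays anchored on compound 1 at 26200 nM. The expected result is a 1.0-fold lower number from compound 1 to compound 3 (0.02 log units; within the scatter), a small step with no favoured direction and probably none beyond the usual scatter. For compound 3 the estimated value is 25000 nM, with an expected range from 9000 nM to 70000 nM.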

Compound 3, half-maximal inhibitory concentration: 28400 nM
Beside the measured number, compound 3's estimate is 1.1-fold (0.06 log units) below it; low and high end bracket the measured number.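

In this assay, among the compounds shown here, adding the methyl gives a 1.1-fold higher number from compound 1 to compound 3 (0.04 log units; within the scatter), the first direct comparison in this set between two compounds that differ in one place. It shows that going from phenyl to 4-methylphenyl, with one added carbon on the aromatic ring and para to a large group, produces no readable shift in cytotoxicity, so this position accepts a methyl without a clear gain or loss on this read-out. Compound 2 differs from the other compounds in more than one place and its result is a limit and not a number, so no step can be read from it: the limit of > 100000 nM in this assay, at which 1 of the 3 values shown sits.

On these data alone, a single methyl is only one small probe, so it remains open whether something different at this same place, such as a tert-butyl group, a hydroxyl, an amine or a carboxylic acid, would move the number beyond the usual scatter. Also open, as far as these compounds go, is whether a methyl on another carbon of the same phenyl ring would behave as this one does.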